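The source may report more compounds than this note shows. Statements on the series, on what has been measured and on what is new or still open speak of the compounds shown alone.

Among the measured compounds shown here, compound 1 `Cc1cn(C2CCN(Cc3cccc(OC4CCCC4)c3)CC2)c(=O)[nH]c1=O` is the one member of this small set with a number to its name. In an ADME assay on MRC5 cells (Homo sapiens) for cytotoxicity, read by fluorescence and resazurin assay, with a stated time of 3 days (on this read-out lower numbers stand for stronger inhibition and higher numbers for weaker inhibition), compound 1 gives 30300 nM, so it stands alone on the measured side; compound 2 `Cc1cn(C2CCN(Cc3cccc(Oc4cc(C(F)(F)F)cc(C(F)(F)F)c4)c3)CC2)c(=O)[nH]c1=O`, which carries a different ether group, was run in this assay, but for compound 2 the entry reads "not determined" (no result reported), so no result was reported for it. Compound 3 `Cc1cn(C2CCN(Cc3cccc(OC4CCCCC4)c3)CC2)c(=O)[nH]c1=O` differs from compound 1 in a single place: cyclohexyl in place of cyclopentyl on an oxygen on an aromatic ring. For the measured compounds named here, no step between two measured compounds is available to calibrate a change of this kind, so the expectation rests on compound 1 alone. Since one ring carbon is added and nothing else is altered, the step from compound 1 to compound 3 is expected to be small, a 1.2-fold lower number from compound 1 to compound 3 (0.08 log units; within the scatter), and not clearly beyond the usual scatter in either direction. Compound 3 is therefore estimated to give 25000 nM in this assay, with a likely range from 10000 nM to 60000 nM.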

Compound 3, half-maximal inhibitory concentration: 23600 nM
Compound 3: the middle estimate sits 1.1-fold (0.03 log units) above what was measured; measured number inside the range.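

In this assay, among the compounds shown here, the exchange of cyclopentyl for cyclohexyl on an oxygen on an aromatic ring gives a 1.3-fold lower number from compound 1 to compound 3 (0.11 log units; within the scatter) and provides the first measured step at this position. Compound 1 and compound 3 therefore cannot be told apart on this read-out, which a single measured compound could not show. No measurement at hand gives a reason for this result.

With only these two non-aromatic carbon rings compared, the result says nothing about how an amine, a carboxylic acid or a longer straight chain on this oxygen would read in this assay. Going by these compounds, compound 2 has no reported number, so any step involving its aromatic ether cannot be read, and whether such a group would shift the value remains open.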